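A few compounds are considered here, and "the series" means these few. Any claim that something is new, unique, unknown or untested is made for them only; others in the source may bear on it.

Measured compounds:
compound 1 `CC1=CC[C@@H]([C@@](C)(O)CCCC(C)(C)NC=S)CC1`, 11000 nM in a functional assay on PCO3 cells (Homo sapiens) for cytotoxicity, read by sulforhodamine B assay; on this read-out lower numbers stand for stronger inhibition of growth and higher numbers for weaker inhibition of growth
compound 2 `COc1ccc(/C=N\NC(=S)NC(C)(C)CCC[C@](C)(O)[C@@H]2CC=C(C)CC2)cc1`, 7660 nM in this assay
compound 3 `CC1=CC[C@@H]([C@@](C)(O)CCCC(C)(C)NC(=S)N/N=C\c2ccc(N(C)C)cc2)CC1`, 13700 nM in this assay

Compound 2 stands at the low end of the three numbers in this assay, yet compound 1 and compound 3 both sit within the scatter of it, so the three are not separated.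

Compound 4 `CC1=CC[C@@H]([C@@](C)(O)CCCC(C)(C)NC(=S)N/N=C\c2cccc([N+](=O)[O-])c2)CC1` differs from compound 2 by 3-nitrophenyl in place of 4-methoxyphenyl on a carbon with a double bond to nitrogen. Within the data shown here, the one measured step on the same aromatic ring is a 1.8-fold higher number from compound 2 to compound 3 (0.25 log units; within the scatter), a change of the substituent on that ring that left the number within the scatter. Compound 1, which carries no aryl hydrazone at all, also lies within the scatter of compound 2. Among the measured compounds shown here, nothing among the measured compounds therefore points to a shift beyond the scatter for a further change on this ring, and compound 4 is expected to stay in the same band, with a 1.2-fold higher number from compound 2 to compound 4 (0.09 log units; within the scatter) as the expected step. For compound 4 the estimate in this assay is 9500 nM, within 4000 nM to 23000 nM.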

Compound 4, concentration for 50% growth inhibition: 5600 nM
Compound 4: the middle estimate sits 1.7-fold (0.23 log units) above what was measured; the measured number falls inside the stated range.
By their numbers in this assay, from the lowest: compounds 4, 2, 1 and 3 (each within the scatter of the next, the first and the last beyond it).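

In this assay, among these compounds, the aryl group on the carbon with a double bond to nitrogen now gives the first step that lies beyond the scatter, a modest one for 3-nitrophenyl in place of 4-(dimethylamino)phenyl (a 2.4-fold lower number from compound 3 to compound 4 (0.39 log units; beyond the scatter)). The same group in place of 4-methoxyphenyl does not separate from it (a 1.4-fold lower number from compound 2 to compound 4 (0.14 log units; within the scatter)), so the aryl change matters only in the pair that includes compound 3. Nothing available explains the gap between compound 3 and compound 4.

Both steps change the ring substituent and its place on the ring together, so 4-nitrophenyl would be needed to tell the two apart. Also open, from the compounds shown here alone, is how an unsubstituted phenyl or a carboxylic acid on this ring would read, and whether any aryl group moves beyond the scatter of compound 1.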